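This account rests on a few compounds, and the source may have more. Where it says the series, first, only, none or still open, it means among the compounds named here.

Compound 1 `COc1cc(-c2cc(/C=C/C(=O)c3ccc(N)cc3)[nH]n2)cc(OC)c1OC` and compound 2 `COc1ccc(-c2cc(/C=C/C(=O)c3ccc(N)cc3)[nH]n2)cc1OC` share the same core and differ only in the substitution on the aryl attached to the pyrazole. In a functional assay on PC-3 cells (Homo sapiens) for cytotoxicity, read by sulforhodamine B assay, with a stated time of 48 h, tested at 100 uM (on this read-out higher numbers stand for a weaker effect at the one concentration tested and lower numbers for a stronger effect), compound 1 gives -39% and compound 2 gives -48%; the step of a number 9 percentage points lower from compound 1 to compound 2 (within the scatter) lies within the scatter, so the two numbers cannot be told apart. Among these two measured numbers compound 1 stands highest, and its nearest neighbour is compound 2.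

Compound 3 `COc1cc(-c2cc(/C=C/C(=O)c3ccc(F)c(F)c3)[nH]n2)cc(OC)c1OC` is not yet measured. It differs from compound 1 in the change (3,4-difluorophenyl in place of 4-aminophenyl on a carbonyl carbon), a 3,4-difluorophenyl in place of a 4-aminophenyl on the carbonyl carbon whose other neighbour is a double-bonded chain carbon. Among the measured compounds shown here, the only measured step, which is the one from compound 1 to compound 2 with a hydrogen in place of a methoxy on an aromatic carbon, concerns a different part of the molecule and is within the scatter, so no measured step bears on this change. He therefore expects no step beyond the scatter in this assay, that is a number 4 percentage points higher from compound 1 to compound 3 (within the scatter), while granting a wide range. His estimate for compound 3 is -35%, between -70% and 5%.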

Compound 3, a percentage reported as activity, at one concentration (the size of the read-out at that concentration, not a potency): -41%
For compound 3 the middle estimate is 6 percentage points above the measured one; the range from low to high includes it.
By their numbers in this assay, from the lowest: compounds 2, 3 and 1 (each within the scatter of the next).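

Read in this assay the exchange of 4-aminophenyl for 3,4-difluorophenyl on the carbonyl carbon gives a number 2 percentage points lower from compound 1 to compound 3 (within the scatter) and so leaves the two compounds indistinguishable on this read-out. Among the compounds shown here, this is the first measured change at this place, since the earlier pair differed only by a methoxy on an aromatic carbon elsewhere in the molecule, and it shows that this position can carry either ring without a step beyond the scatter at the one concentration tested. The exchange also removes the nitrogen and the hydrogen-bond donor and acceptor counted for 4-aminophenyl, and the read-out stays within the scatter without them, at least for this single pair on the core of compound 1.

On these data alone, whether the same holds for a plain phenyl, a carboxylic acid or a longer chain on this carbonyl carbon stays open, as does whether a single concentration hides a difference in potency between these compounds that a full dose-response curve would reveal. Nothing available here explains why the two groups read alike.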